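The compounds below may be only part of what the source reports. "The series", "measured", "known", "first", "only" and "open" are said of these compounds alone.

Compound 1 `O=C1CS/C(=N/Nc2nncc3ccccc23)N1c1ccccc1` gives 97 nM
Compound 2 `CCN1C(=O)CS/C1=N/Nc1nncc2ccccc12` gives 86 nM

Among the measured compounds shown here, in a functional assay on DU-145 cells (Homo sapiens) for antiproliferative activity, read by sulforhodamine B assay, with a stated time of 72 h (a lower number here means a stronger inhibitor, a higher number a weaker inhibitor), compound 2 gives 86 nM and stands within the scatter of compound 1, the only other measured compound. Going from compound 2 to compound 3 `O=C1CS/C(=N/Nc2nncc3ccccc23)N1` brings hydrogen in place of ethyl on an amide-type nitrogen in a ring and so puts hydrogen in place of ethyl on an amide-type nitrogen in a ring. For the measured compounds named here, one measured step bears on this nitrogen, a 1.1-fold lower number from compound 1 to compound 2 (0.05 log units; within the scatter) with ethyl in place of phenyl. Going by the values given here, no measured compound carries hydrogen there, so a wide range is kept, but no step beyond the scatter is expected. The expected step is a 1.2-fold higher number from compound 2 to compound 3 (0.07 log units; within the scatter) and no more. For compound 3 the estimated value is 100 nM with an expected range from 35 nM to 300 nM.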

Compound 3, half-maximal inhibitory concentration: 67 nM
Estimate against measurement, compound 3: 1.5-fold (0.17 log units) above; low and high end bracket the measured number.
By their numbers in this assay, from the lowest: compounds 3, 2 and 1 (each within the scatter of the next).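

In this assay hydrogen on the amide-type nitrogen in the ring stands within the scatter of both ethyl (a 1.3-fold lower number from compound 2 to compound 3 (0.11 log units; within the scatter)) and phenyl (a 1.4-fold lower number from compound 1 to compound 3 (0.16 log units; within the scatter)). Across compounds 1, 2 and 3, then, the read-out does not depend on a carbon substituent at this nitrogen, whether ethyl, phenyl or none at all. No evidence here bears on why this is so. Still open, as far as these compounds go, is whether a longer chain, an amine or a carboxylic acid on this nitrogen would stay within the same range.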